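The source may report more compounds than this note shows. Statements on the series, on what has been measured and on what is new or still open speak of the compounds shown alone.

Compound 1 `CC(C(=O)NCc1ccc(C(F)(F)F)cc1SC1CCCCC1)c1ccc(NS(C)(=O)=O)c(F)c1` gives 0.5 nM in an assay on CHO cells for antagonist activity at transient receptor potential cation channel subfamily V member 1 (Homo sapiens), read by FLIPR; on this read-out lower numbers stand for stronger inhibition and higher numbers for weaker inhibition.
Compound 2 `COc1ccc(CSc2cc(C(F)(F)F)ccc2CNC(=O)C(C)c2ccc(NS(C)(=O)=O)c(F)c2)cc1` gives 2.3 nM in this assay.

Going by the values given here, compound 2 stands at the higher of the two numbers: its only neighbour is compound 1, and the step of a 4.6-fold higher number from compound 1 to compound 2 (0.66 log units; beyond the scatter) is the one measured change, a 4-methoxybenzyl in place of cyclohexyl on a sulfur. Compound 3 `CC(C(=O)NCc1ccc(C(F)(F)F)cc1-c1ccc(F)c(Cl)c1)c1ccc(NS(C)(=O)=O)c(F)c1` is not yet measured. It differs from compound 2 by 3-chloro-4-fluorophenyl in place of (4-methoxybenzyl)sulfanyl on an aromatic carbon. Among the compounds with values here, no measured step shares this change; the sulfur-linked group is removed entirely and an aromatic ring is attached directly to the core. The step from compound 1 to compound 2 only shows that the group at this place moves the number by a modest amount. The expected step of a 1.9-fold lower number from compound 2 to compound 3 (0.28 log units; within the scatter) in this assay is therefore small and of uncertain direction. Compound 3 is estimated at 1.2 nM in this assay, with a range from 0.25 nM to 6 nM.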

Compound 3, inhibition constant: 0.6 nM
For compound 3 the middle estimate is 2.0-fold (0.30 log units) above the measured one; measured number inside the range.
By their numbers in this assay, from the lowest: compounds 1 and 3 (each within the scatter of the next); then compound 2.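

At this aromatic carbon, the group need not be joined through sulfur: 3-chloro-4-fluorophenyl, a ring attached directly, in place of (4-methoxybenzyl)sulfanyl gives (a 3.8-fold lower number from compound 2 to compound 3 (0.58 log units; beyond the scatter)) in this assay. The same ring in place of cyclohexylsulfanyl gives (a 1.2-fold higher number from compound 1 to compound 3 (0.08 log units; within the scatter)), so compound 1 and compound 3 cannot be told apart on this read-out, although one carries a sulfur link and the other does not. Among these three groups, then, the sulfur link alone does not set the number, and only the (4-methoxybenzyl)sulfanyl of compound 2 stands apart.

Going by these compounds, it remains open how a plain phenyl ring without chlorine or fluorine, or an amine such as morpholine, would read at this carbon. Nothing available here explains why these groups give the numbers they do.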